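A few compounds are considered here, and "the series" means these few. Any claim that something is new, unique, unknown or untested is made for them only; others in the source may bear on it.

In a functional assay on MDA-MB-231 cells (Homo sapiens) for inhibition, read by sulforhodamine B assay, with a stated time of 72 h (a lower number here means a stronger inhibitor of growth, a higher number a weaker inhibitor of growth), compound 1 `CCOC(=O)/C=C/c1ccncc1-c1ccc2ccccc2c1` gives 8090 nM. Compound 2 `O=C(O)/C=C/c1ccncc1-c1ccc2ccccc2c1` gives > 10000 nM, which is a limit of the assay and not a number. Compound 3 `NC(=O)/C=C/c1ccncc1-c1ccc2ccccc2c1` gives > 10000 nM, also a limit. As far as these compounds go, compound 3 therefore stands at the limit of > 10000 nM in this assay, at which 2 of the 3 values shown sit, and its true value is unknown.

The next compound, compound 4 `O=C(O)CCc1ccncc1-c1ccc2ccccc2c1`, has 2-carboxyethyl in place of 2-carbamoylethenyl on an aromatic carbon.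

For the measured compounds named here, three measured steps bear on this change, and none gives a firm size. There is an at least 1.2-fold higher number from compound 1 to compound 2 (0.09 log units; that floor lies within the scatter), and there is an at least 1.2-fold higher number from compound 1 to compound 3 (0.09 log units; that floor lies within the scatter). Between the two limits there is a step that the two limits leave unreadable from compound 2 to compound 3. Going by the values given here, compound 4 shares its carboxylic acid with compound 2, but no measured step shows what happens when the chain loses its carbon-carbon double bond.

With so little to go on, no clear gain is expected, and compound 4 is expected to stay close to the limit reached by compound 2 and compound 3. The expected size is a step that the limit leaves unreadable from compound 3 to compound 4, an estimate that cannot be read sharply from a limit. For compound 4 the estimated value is 14000 nM, with an expected range from 6000 nM to 30000 nM, and the assay may well report only a limit.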

Compound 4, concentration for 50% growth inhibition: > 10000 nM
Compound 4: no number, only a limit; the forecaster's own chance of this, stated with the estimate: 80%; the middle value does not contradict the limit.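

In this assay compound 4 gives > 10000 nM, which is a limit of the assay and not a number. For the compounds shown here, the one step that can be read is an at least 1.2-fold higher number from compound 1 to compound 4 (0.09 log units; that floor lies within the scatter), while the steps linking compound 4 to compound 2 and to compound 3 cannot be read. At this position, on an aromatic carbon opposite the ring nitrogen, removing the carbon-carbon double bond from the acid chain of compound 2 therefore does not produce a readable number, and one more compound joins the others at the limit: the limit of > 10000 nM in this assay, at which 3 of the 4 values shown sit.

Among the compounds shown, only compound 1, with its 2-(ethoxycarbonyl)ethenyl chain, gives a number, so it remains open what removing the double bond does when the chain ends in an ethyl ester, as a 2-(ethoxycarbonyl)ethyl group would show. As far as these compounds go, it is also open whether a chain ending in an amine, or a longer chain ending in a carboxylic acid, would give a readable number at this position.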